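The source may hold more compounds than are shown below. What is called first, only, known or untested is meant among the compounds shown, and "the series" means these compounds.

Compound 1 `CN1CCc2cc(Cl)c(NS(=O)(=O)c3ccc(-c4ccc(Cl)cc4)cc3)cc2CC1` is one of two compounds tested in an assay on isolated protein for displacement of a labelled ligand from 5-hydroxytryptamine receptor 6 (Homo sapiens), read by radioligand binding; on this read-out higher numbers stand for weaker inhibition and lower numbers for stronger inhibition; compound 1 gives 50.1 nM. The other, compound 2 `Cc1cc(S(=O)(=O)Nc2ccc3c(c2)CCN(C)CC3)ccc1-c1ccc(Cl)cc1`, gives 5.01 nM, a lower number, and this gap lies beyond the usual scatter, so compound 1 has the higher of the two numbers. Compound 3 `CC(C)c1cc2c(cc1NS(=O)(=O)c1ccc(-c3ccc(Cl)cc3)cc1)CCN(C)CC2` differs from compound 1 in one place: isopropyl in place of chloro on an aromatic carbon. For the measured compounds named here, no pair measured here shows this kind of change, so its effect is unknown; a small step, if any, within the scatter seems the most sensible expectation. On that basis compound 3 is estimated at 35 nM, within 10 nM to 120 nM, an expected step of a 1.4-fold lower number from compound 1 to compound 3 (0.16 log units; within the scatter).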

Compound 3, inhibition constant: 12.6 nM
For compound 3 the middle estimate is 2.8-fold (0.44 log units) above the measured one; low and high end bracket the measured number.
By their numbers in this assay, from the lowest: compound 2; then compound 3; then compound 1.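

Putting isopropyl in place of chloro on this aromatic carbon gives a 4.0-fold lower number from compound 1 to compound 3 (0.60 log units; beyond the scatter), so the number falls even though three heavy atoms replace one. The position therefore tolerates a group with more atoms than chloro, and chloro is not required here for a number in this range. Nothing available explains this step.

From the compounds shown here alone, how other groups behave at this carbon stays open, for example methyl, methoxy or an amine. It is also unclear whether a longer chain such as butyl would lower the number further or raise it.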